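Cutting Away the Nitrile Chain: Compound 3 to Compound 4

The source may hold more compounds than are shown below. What is called first, only, known or untested is meant among the compounds shown, and "the series" means these compounds.

Measured so far:
compound 1, `C=CCc1cc(C(C)=O)c(O)cc1OCCCCCC#N`, 81%
compound 2, `C=CCc1cc(C(C)=O)c(O)cc1OCCCCCCC#N`, 97%
compound 3, `C=CCc1cc(C(C)=O)c(O)cc1OCCCCCCCCCCC#N`, 50%

Three compounds share one core and differ only in the chain that hangs from the aromatic oxygen, each chain ending in a nitrile. In an assay on isolated protein for inhibition of leukotriene B4 receptor 1 (Homo sapiens), tested at 10 uM (on this read-out lower numbers stand for less inhibition and higher numbers for more inhibition at the one concentration tested (going by the name of the read-out)), compound 1 gives 81%, compound 2 gives 97% and compound 3 gives 50%. Compound 3 stands lowest of the three: the steps of a number 31 percentage points lower from compound 1 to compound 3 (beyond the scatter) and a number 47 percentage points lower from compound 2 to compound 3 (beyond the scatter) both run beyond the scatter, while the step of a number 16 percentage points higher from compound 1 to compound 2 (beyond the scatter) is smaller. Within this set, the longest chain gives the lowest number and the middle chain the highest.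

Compound 4, `C=CCc1cc(C(C)=O)c(O)cc1OCCCC`, is reached from compound 3 by a change in the same chain: hydrogen in place of 6-cyanohexyl on a saturated chain carbon, four bonds along the chain from an oxygen on an aromatic ring. Among the measured compounds shown here, all three measured steps change the chain length while keeping the nitrile, so they bear only partly on this step; no measured step removes the nitrile. Because the steps of a number 31 percentage points lower from compound 1 to compound 3 (beyond the scatter) and a number 47 percentage points lower from compound 2 to compound 3 (beyond the scatter) show a long chain giving the lowest number, a shorter chain is expected to give a number near or somewhat above that of compound 3, with wide uncertainty. Compound 4 is therefore estimated at 55%, between 20% and 85%, a step of a number 5 percentage points higher from compound 3 to compound 4 (within the scatter) that is expected to stay close to the scatter.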

Compound 4, a percentage reported as inhibition, at one concentration (the size of the read-out at that concentration, not a potency): 32%
Beside the measured number, compound 4's estimate is 23 percentage points above it; the measured number falls inside the stated range.
By their numbers in this assay, from the lowest: compound 4; then compound 3; then compound 1; then compound 2.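

In this assay, replacing the 6-cyanohexyl group with hydrogen gives a number 18 percentage points lower from compound 3 to compound 4 (beyond the scatter) and places compound 4 below all three compounds with a nitrile-ended chain, so the earlier finding that the longest nitrile chain gave the lowest number no longer describes the whole set. The drop is much greater when the comparison starts from the shorter nitrile chains: replacing 2-cyanoethyl with hydrogen gives a number 65 percentage points lower from compound 2 to compound 4 (beyond the scatter) and replacing cyanomethyl with hydrogen gives a number 49 percentage points lower from compound 1 to compound 4 (beyond the scatter) in the same measurement. Nothing in the information available explains why the chain without a nitrile gives the lowest number.

The nitrile and chain length change together in these comparisons, so the compounds shown cannot tell whether the nitrile end, the extra chain length or both account for the higher numbers. A plain saturated chain as long as the chain of compound 2 would address that question, while the same chain ending in an amine or a carboxylic acid would show how much the higher number depends on having a nitrile at the chain end.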